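The source may hold more compounds than are shown below. What is called first, only, known or untested is meant among the compounds shown, and "the series" means these compounds.

In an assay on isolated protein for inhibition of ATP-dependent RNA helicase SUPV3L1, mitochondrial (Homo sapiens) (on this read-out higher numbers stand for weaker inhibition and lower numbers for stronger inhibition), compound 3 `CCCCCCCCCCCCCCCCNc1nc(=O)c2ncn([C@@H]3O[C@H](CO)[C@@H](O)[C@H]3O)c2c(=O)[nH]1` gives 30 ug/mL, and compound 2 `CCCCCCCCCCCCCCNc1nc(=O)c2ncn([C@@H]3O[C@H](CO)[C@@H](O)[C@H]3O)c2c(=O)[nH]1` gives 30 ug/mL in this assay, so the two stand level. For compound 1 `CCCCCCCCCCCCNc1nc(O)c2ncnc-2c(O)n1` this assay records only a limit, > 500 ug/mL. Compound 4 `CCCCCCCCCCCCCCCCCCNc1nc(=O)c2ncn([C@@H]3O[C@H](CO)[C@@H](O)[C@H]3O)c2c(=O)[nH]1` differs from compound 3 by ethyl in place of hydrogen on a saturated chain carbon, ten or more bonds along the chain from a nitrogen on an aromatic ring. Among the compounds with values here, one measured step bears directly on this change: no change at the digits printed from compound 2 to compound 3 (within the scatter), which stayed within the scatter. On that footing one expects a step of no change at the digits printed from compound 3 to compound 4 (within the scatter) in this assay, that is, no change beyond the scatter in either direction. The value of compound 4 in this assay is therefore estimated at 30 ug/mL, with a range from 15 ug/mL to 60 ug/mL.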

Compound 4, half-maximal inhibitory concentration: 30 ug/mL
Beside the measured number, compound 4's estimate shows no gap at the digits printed; the measured number falls inside the stated range.
By their numbers in this assay, from the lowest: compounds 2, 3 and 4 (each within the scatter of the next). At a limit, above all of these: compound 1.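

In this assay, within the data shown here, the single flat step seen earlier now repeats one ethyl further along the chain: no change at the digits printed from compound 3 to compound 4 (within the scatter). Taken over the whole span, with butyl in place of hydrogen, the reading is the same: no change at the digits printed from compound 2 to compound 4 (within the scatter). Nothing in the data at hand accounts for this flat run.

As far as these compounds go, whether a longer chain would also leave the value in this assay unmoved remains open. So does the effect of an amine or a carboxylic acid in place of the ethyl.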